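The compounds below may be only part of what the source reports. "The series", "measured", "known", "first", "only" and "open" are said of these compounds alone.

In a functional assay on brain (Rattus norvegicus, strain Wistar) for inhibition (on this read-out lower numbers stand for stronger inhibition and higher numbers for weaker inhibition), compound 1 `CCCc1ccc(-c2c(C)[nH]c(=O)n2C2CCCCC2)cc1` gives 13900 nM, compound 2 `CCCCCCCc1ccc(-c2c(C)[nH]c(=O)n2C2CCCCC2)cc1` gives 8700 nM, and compound 3 `CCCCCCCCc1ccc(-c2c(C)[nH]c(=O)n2C2CCCCC2)cc1` gives 10300 nM. Compound 3 therefore sits within the scatter of both other compounds. Compound 4 `CCCCCCCCCCCCCCc1ccc(-c2c(C)[nH]c(=O)n2C2CCCCC2)cc1` differs from it by hexyl in place of hydrogen on a saturated chain carbon, eight bonds along the chain from an aromatic carbon. The measured steps that bear on this change also extend the chain: a 1.6-fold lower number from compound 1 to compound 2 (0.20 log units; within the scatter), a 1.3-fold lower number from compound 1 to compound 3 (0.13 log units; within the scatter) and a 1.2-fold higher number from compound 2 to compound 3 (0.07 log units; within the scatter). None leaves the scatter, although the hexyl addition goes beyond the butyl, pentyl and methyl additions measured so far. No clear change is therefore expected in this assay. The expected step is a 1.1-fold lower number from compound 3 to compound 4 (0.06 log units; within the scatter). For compound 4, the estimated value is 9000 nM, with an expected range of 3000 nM to 25000 nM.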

Compound 4, half-maximal inhibitory concentration: > 100000 nM
Compound 4: no number, only a limit; the forecaster's own chance of this, stated with the estimate: 10%; middle value at least 11-fold (1.04 log units) from the limit.
By their numbers in this assay, from the lowest: compounds 2, 3 and 1 (each within the scatter of the next). At a limit, above all of these: compound 4.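

In this assay compound 4 carries no number, only a limit: the limit of > 100000 nM in this assay, at which 1 of the 4 values shown sits. The earlier chain extensions all stayed within the scatter, but the hexyl addition at this place, eight bonds along the chain from an aromatic carbon, does not: an at least 9.7-fold higher number from compound 3 to compound 4 (0.98 log units; beyond the scatter), an at least 11-fold higher number from compound 2 to compound 4 (1.06 log units; beyond the scatter) and an at least 7.1-fold higher number from compound 1 to compound 4 (0.85 log units; beyond the scatter). Among these compounds, then, chain extension stops being neutral somewhere up to this length, and inhibition weakens beyond the scatter.

Where along the chain that loss sets in stays open, as does how far the true number of compound 4 lies past its limit. It is also unknown whether an amine or a carboxylic acid in place of the hexyl would behave the same way.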